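Swapping the outer ring for a dimethyl-isoxazole

The source may report more compounds than this note shows. Statements on the series, on what has been measured and on what is new or still open speak of the compounds shown alone.

Measured so far in a functional assay on CHO cells for agonist activity at Free fatty acid receptor 1 (Homo sapiens), read by FLIPR and calcium flux; a lower number here means that less compound is needed, a higher number that more compound is needed for the effect:
- compound 1 `O=C(O)COc1ccc(NCc2cccc(-c3ccccc3Cl)c2)cc1F`: 19.3 nM
- compound 2 `N#Cc1ccccc1-c1cccc(CNc2ccc(OCC(=O)O)c(F)c2)c1`: 729 nM
- compound 3 `COc1ccccc1-c1cccc(CNc2ccc(OCC(=O)O)c(F)c2)c1`: 536 nM

Compound 3 stands second highest of the three numbers; it sits close to compound 2, since a 1.4-fold lower number from compound 2 to compound 3 (0.13 log units; within the scatter), while compound 1 is far away, since a 28-fold higher number from compound 1 to compound 3 (1.44 log units; beyond the scatter). The three compounds share one core and differ only in the group on the outer aromatic ring: a 38-fold higher number from compound 1 to compound 2 (1.58 log units; beyond the scatter) shows how strongly that single group can move the number.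

Compound 4 `Cc1noc(C)c1-c1cccc(CNc2ccc(OCC(=O)O)c(F)c2)c1` replaces the whole outer ring: 3,5-dimethyl-1,2-oxazol-4-yl in place of 2-methoxyphenyl on an aromatic carbon. Within the data shown here, no measured step exchanges one ring for another; the three measured steps only vary a single group on the same ring, and two of them were large while the third stayed within the scatter. As far as these compounds go, compound 4 is therefore expected to stay near compound 3, with the change estimated as a 1.2-fold higher number from compound 3 to compound 4 (0.08 log units; within the scatter), and a wide range is kept because the ring swap is untested. For compound 4 the estimate in this assay is 650 nM, with a range from 150 nM to 2800 nM.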

Compound 4, half-maximal effective concentration: 225 nM
For compound 4 the middle estimate is 2.9-fold (0.46 log units) above the measured one; low and high end bracket the measured number.
By their numbers in this assay, from the lowest: compound 1; then compound 4; then compounds 3 and 2 (each within the scatter of the next).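

In this assay, the outer ring need not be a six-membered aromatic ring of carbon only: the step to 3,5-dimethyl-1,2-oxazol-4-yl, a five-membered aromatic ring with 2 hetero atoms, gives a 2.4-fold lower number from compound 3 to compound 4 (0.38 log units; beyond the scatter) and also a 3.2-fold lower number from compound 2 to compound 4 (0.51 log units; beyond the scatter), so this ring swap improves on both the methoxy and the cyano compounds. The 2-chlorophenyl group still keeps a clear lead, with a 12-fold higher number from compound 1 to compound 4 (1.07 log units; beyond the scatter), which means the new ring closes only part of the gap that separates those two compounds from compound 1. Nothing available here explains why these groups differ.

The compounds shown leave open whether the two methyl groups on the new ring are needed, since a 1,2-oxazole ring carrying one methyl or none does not appear among them. As far as these compounds go, it also remains open whether a phenyl ring with bromo or trifluoromethyl in place of chloro would match compound 1.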